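A few compounds are considered here, and "the series" means these few. Any claim that something is new, unique, unknown or untested is made for them only; others in the source may bear on it.

Measured compounds:
compound 1 `Clc1ncccc1OC[C@@H]1CCN1` — 0.0084 nM
compound 2 `Brc1ncccc1OC[C@@H]1CCN1` — 0.24 nM

In an assay on brain for binding affinity to Neuronal acetylcholine receptor; alpha4/beta2 (Rattus norvegicus) (a lower number here means a stronger inhibitor, a higher number a weaker inhibitor), compound 2 gives the higher of the two numbers; its nearest neighbour is compound 1, with a 29-fold higher number from compound 1 to compound 2 (1.46 log units; beyond the scatter) standing between them. The step to compound 3 `Ic1ncccc1OC[C@@H]1CCN1` is iodo in place of bromo on an aromatic carbon. Going by the values given here, only one measured step bears on this change, a 29-fold higher number from compound 1 to compound 2 (1.46 log units; beyond the scatter), which went from chloro to bromo and was large. Extending the series one halogen further, compound 3 is expected to give a weaker number again, with a 6.3-fold higher number from compound 2 to compound 3 (0.80 log units; beyond the scatter) estimated. The estimate for compound 3 is 1.5 nM, with a range from 0.3 nM to 8 nM.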

Compound 3, inhibition constant: > 0.001 nM
Compound 3 ended at the assay's limit (the forecaster's own chance of this, stated with the estimate: 2%); the middle value is on the limit's open side.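

Compound 3 gives > 0.001 nM, which is a limit of the assay and not a number, so its steps from compound 1 and compound 2 cannot be read. The compounds shown leave open where iodo stands relative to chloro and bromo.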